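This account rests on a few compounds, and the source may have more. Where it says the series, first, only, none or still open, it means among the compounds named here.

Measured in an ADME assay on Jejunum (Mus musculus, strain C57BL/6) for metabolic stability, read by HPLC, with a stated time of 12 h; on this read-out lower numbers stand for a shorter-lived compound and higher numbers for a longer-lived compound; each entry is a limit of the assay, not a number:
- compound 1 `O=C(O)[C@@H](CO)NC(=O)[C@H]1C[C@H](O)CN1`: > 12 h
- compound 2 `O=C(N[C@H](CO)C(=O)O)[C@@H]1C[C@H](O)CN1`: > 12 h
- compound 3 `O=C(O)[C@H](CO)NC(=O)[C@H]1C[C@@H](O)CN1`: > 12 h

Compound 3 stands at the same limit as the other two, so its place in the series has no numerical rank. This is the limit of > 12 h in this assay, at which 3 of the 3 values shown sit.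

Not yet measured is compound 4 `O=C(O)[C@H](CO)NC(=O)[C@@H]1C[C@H](O)CN1`. Relative to compound 3, the change is the two compounds have the same atoms and bonds and differ only in configuration as drawn: 2 of 3 stereo elements differ; a stereocentre at a saturated ring carbon is drawn R in compound 3 and S in compound 4; a stereocentre at a saturated ring carbon is drawn R in compound 3 and S in compound 4. The two compounds have the same atoms and bonds, and both ring stereocentres are drawn R in compound 3 and S in compound 4.

The closest evidence is also configurational: a step that the two limits leave unreadable from compound 1 to compound 2, a step that the two limits leave unreadable from compound 1 to compound 3 and a step that the two limits leave unreadable from compound 2 to compound 3. None of these has a readable size, yet no configuration tested so far has left the limit, including the fully inverted pair of compound 2 and compound 3.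

No step beyond the usual scatter and no direction is therefore expected in this assay. The expected change is a step that the limit leaves unreadable from compound 3 to compound 4. Compound 4 is expected to be reported only as a limit. As a number, compound 4 is estimated at 14 h, with an expected range of 10 h to 24 h.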

Compound 4, half-life: 0.39 h
The estimate for compound 4 lay 36-fold (1.56 log units) above the measured number, and the stated range ends above it.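

In this assay configuration now has a readable effect: inverting only the saturated chain stereocentre gives an at least 30-fold lower number from compound 2 to compound 4 (1.48 log units; beyond the scatter), inverting both ring stereocentres gives an at least 30-fold lower number from compound 3 to compound 4 (1.48 log units; beyond the scatter), and inverting the chain stereocentre with one ring stereocentre gives an at least 30-fold lower number from compound 1 to compound 4 (1.48 log units; beyond the scatter). Of the four configurations, only compound 4 is off the limit, although compound 2 shares its ring stereocentres and compound 3 shares its chain stereocentre, so in these compounds neither feature alone goes with the short half-life, only the combination. No atom or bond changes in the single-centre case: the fact that compounds 2 and 4 differ only in the configuration as drawn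

On these data alone, compounds 1, 2 and 3 all sit at the assay limit, so the steps among them cannot be read and their actual half-lives stay unknown. As far as these compounds go, whether the same dependence on configuration holds with a methyl ester in place of the carboxylic acid, or a methoxy group in place of the hydroxyl, stays open.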